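A second chloro group on compound 2

A few compounds are considered here, and "the series" means these few. Any claim that something is new, unique, unknown or untested is made for them only; others in the source may bear on it.

In a functional assay on MT4 cells (Homo sapiens) for cytotoxicity (on this read-out lower numbers stand for stronger inhibition and higher numbers for weaker inhibition), compound 1 `N#Cc1c(N)cccc1S(=O)(=O)c1ccccc1` gives > 5000 nM, which is a limit. Compound 2 `N#Cc1c(N)cccc1S(=O)(=O)c1cccc(Cl)c1` gives > 200000 nM, also a limit, so its standing is known only as that limit. Compound 3 `N#Cc1c(N)cccc1S(=O)(=O)c1cc(Cl)cc(Cl)c1` differs from compound 2 by chloro in place of hydrogen on an aromatic carbon. For the measured compounds named here, the only measured step of this kind is a step that the two limits leave unreadable from compound 1 to compound 2, and it offers no size to carry over. With so little to go on, only a modest change is expected. The estimated step is an at least 1.3-fold lower number from compound 2 to compound 3 (0.12 log units; that floor lies within the scatter), small and towards stronger inhibition. For compound 3 the expected value is 150000 nM, with an estimated range of 30000 nM to 400000 nM.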

Compound 3, half-maximal inhibitory concentration: > 200000 nM
Compound 3: a limit, no number (the forecaster's own chance of this, stated with the estimate: 55%); middle value at least 1.3-fold (0.12 log units) from the limit.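

No step can be read from compound 2 to compound 3, since both stand only as limits in this assay: the limit of > 200000 nM in this assay, at which 2 of the 3 values shown sit.

The compounds shown leave open whether a second chloro group changes the read-out at all, and what real value any of the three compounds has.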